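Moving the Methoxy Group: From Compound 1 to Compound 4

The compounds below may be only part of what the source reports. "The series", "measured", "known", "first", "only" and "open" are said of these compounds alone.

Compound 1 `COc1ccccc1/C=C/C(=O)OC/C=C/c1cc(OC)c(OC)cc1OC` gives 50% in a functional assay on the whole organism (strain Kunming) with Mus musculus as the target, with a stated time of 0.5 h, at a dose of 300 mg/kg by the intraperitoneal route (a lower number here means a stronger effect, a higher number a weaker effect of the compound at the dose given), the highest of the three measured numbers. Compound 2 `COc1cc(OC)c(OC)cc1/C=C/COC(=O)/C=C/c1ccc(OC)c(OC)c1` gives 0% and compound 3 `COc1cc(OC)c(OC)cc1/C=C/COC(=O)/C=C/c1cc(OC)c(OC)c(OC)c1OC` gives 0%, both standing beyond the scatter below compound 1. Compound 4 `COc1cccc(/C=C/C(=O)OC/C=C/c2cc(OC)c(OC)cc2OC)c1` differs from compound 1 by 3-methoxyphenyl in place of 2-methoxyphenyl on a double-bonded chain carbon bound to a double-bonded chain carbon. Within the data shown here, the one measured step that bears on this change is a number 50 percentage points lower from compound 1 to compound 2 (beyond the scatter), a large loss when the same 2-methoxyphenyl was replaced by another group at the same place. Among the measured compounds shown here, no measured compound carries a 3-methoxyphenyl there, so the expectation rests on that single step, and a loss beyond the scatter is expected, though possibly a smaller one. For compound 4 the estimated value is 20%, within 0% to 50%. The expected step is a number 30 percentage points lower from compound 1 to compound 4 (beyond the scatter).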

Compound 4, a percentage reported as activity, at one dose (the size of the read-out at that dose, not a potency): 50%
Estimate against measurement, compound 4: 30 percentage points below; the range from low to high includes it.
By their numbers in this assay, from the lowest: compounds 2 and 3 (each within the scatter of the next); then compounds 1 and 4 (each within the scatter of the next).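

In this assay, 3-methoxyphenyl in place of 2-methoxyphenyl on a double-bonded chain carbon leaves the read-out unmoved (no change at the digits printed from compound 1 to compound 4 (within the scatter)), so at this place the change tolerated here is the shift of the single methoxy. The large difference instead appears with one methoxy more or less on the ring (a number 50 percentage points higher from compound 2 to compound 4 (beyond the scatter)), which marks the methoxy count, not the shift, as the change that matters among these compounds. No measured evidence bears on why this is so. Going by these compounds, what a hydroxy group, an amine or a carboxylic acid on this ring would give remains open.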